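Working notes: the step from compound 3 to compound 4

The source may hold more compounds than are shown below. What is called first, only, known or untested is meant among the compounds shown, and "the series" means these compounds.

Measured in a functional assay on U-373MG ATCC cells (Homo sapiens) for inhibition, read by MTT assay, with a stated time of 72 h; on this read-out higher numbers stand for weaker inhibition and lower numbers for stronger inhibition:
compound 1 `COc1ccc(NC(=S)NC2CC(C)(C)Oc3ccc(Br)cc32)cc1`: 40000 nM
compound 2 `CC1(C)CC(NC(=S)Nc2ccc([N+](=O)[O-])cc2)c2cc(Br)ccc2O1`: 9000 nM
compound 3 `COc1cccc(NC(=S)NC2CC(C)(C)Oc3ccc(Br)cc32)c1`: 66000 nM

Compound 3 gives 66000 nM, the highest of the three numbers but within the scatter of compound 1. Compound 2 at 9000 nM lies clearly lower than both.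

The next compound is compound 4 `CC1(C)CC(NC(=S)Nc2ccc(C#N)cc2)c2cc(Br)ccc2O1`, which differs from compound 3 in one place: 4-cyanophenyl in place of 3-methoxyphenyl on an amide-type nitrogen. In words, this is 4-cyanophenyl in place of 3-methoxyphenyl on an amide-type nitrogen.

Among the measured compounds shown here, two measured steps bear on this change. The first, a 1.7-fold higher number from compound 1 to compound 3 (0.22 log units; within the scatter), exchanges 4-methoxyphenyl for 3-methoxyphenyl, so compound 1 and compound 3 can serve as one starting level. For the measured compounds named here, the second, a 4.4-fold lower number from compound 1 to compound 2 (0.65 log units; beyond the scatter), puts nitro in place of methoxy and is the nearest precedent, though a modest one. The series holds no measured nitrile, so carrying the nitro step over to compound 4 is analogy only, resting on a single pair.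

A modest fall in this assay is therefore expected, and the estimated step is a 4.4-fold lower number from compound 3 to compound 4 (0.64 log units; beyond the scatter). For compound 4 the estimated value is 15000 nM, with an expected range from 6000 nM to 40000 nM.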

Compound 4, half-maximal inhibitory concentration: 22000 nM
For compound 4 the middle estimate is 1.5-fold (0.17 log units) below the measured one; low and high end bracket the measured number.
By their numbers in this assay, from the lowest: compound 2; then compounds 4, 1 and 3 (each within the scatter of the next, the first and the last beyond it).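

In this assay, 4-cyanophenyl in place of 3-methoxyphenyl on an amide-type nitrogen gives a 3.0-fold lower number from compound 3 to compound 4 (0.48 log units; beyond the scatter), whereas cyano in place of methoxy gives a 1.8-fold lower number from compound 1 to compound 4 (0.26 log units; within the scatter), so whether the nitrile registers as a real change at this position depends on which methoxy compound serves as the reference. The comparison with the nitro compound gives a 2.4-fold higher number from compound 2 to compound 4 (0.39 log units; beyond the scatter), which shows that cyano and nitro are not interchangeable here in this assay, and compound 2 keeps the lowest number of the four. Nothing in the data shown explains why these two groups differ or why the reference matters.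

Open, going by these compounds, is whether an amine or a carboxylic acid in place of the nitrile on the same aromatic carbon would fall with the nitro compound, with the nitrile compound or with the methoxy compounds. Also open, on these data alone, is whether the gap between cyano and nitro would persist on a core with chlorine in place of the bromine of the core of compound 1.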